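A few compounds are considered here, and "the series" means these few. Any claim that something is new, unique, unknown or untested is made for them only; others in the source may bear on it.

Compound 1 `CN(C)c1ncnc2c1c(-c1ccoc1)cn2[C@@H]1O[C@H](CO)[C@@H](O)[C@H]1O` and compound 2 `CN(C)c1ncnc2c1c(-c1ccsc1)cn2[C@@H]1O[C@H](CO)[C@@H](O)[C@H]1O` share a core and differ in one group on an aromatic carbon: furan-3-yl in compound 1 and thiophen-3-yl in compound 2. Compound 3 `C#Cc1cn([C@@H]2O[C@H](CO)[C@@H](O)[C@H]2O)c2ncnc(N(C)C)c12` carries ethynyl there instead.

In an ADME assay on MRC5 cells (Homo sapiens), read by MTT assay, with a stated time of 72 h (a lower number here means a stronger inhibitor, a higher number a weaker inhibitor), compound 1 gives > 100000 nM, which is a limit of the assay and not a number. Compound 2 gives > 100000 nM, also a limit, so it stands at the limit of > 100000 nM in this assay, at which 2 of the 3 values shown sit. This leaves a step that the two limits leave unreadable from compound 1 to compound 2. Compound 3 gives a true number, 36100 nM. The ethynyl change therefore produces an at least 2.7-fold lower number from compound 2 to compound 3 (0.44 log units; beyond the scatter), and likewise an at least 2.7-fold lower number from compound 1 to compound 3 (0.44 log units; beyond the scatter).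

Compound 4 `Cc1ncnc2c1c(-c1ccsc1)cn2[C@@H]1O[C@H](CO)[C@@H](O)[C@H]1O` keeps the thiophen-3-yl of compound 2 but has methyl in place of dimethylamino on an aromatic carbon. Among the compounds with values here, no measured step changes this group, so the evidence is only indirect. The ethynyl steps show that one change on this core can bring a number within the range of this assay, as compound 3 does at 36100 nM. A lower number is therefore expected, though a result still at the limit is quite possible. The expected change is an at least 2.5-fold lower number from compound 2 to compound 4 (0.39 log units; beyond the scatter). The estimate for compound 4 is 40000 nM, with an expected range of 5000 nM to 100000 nM.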

Compound 4, half-maximal inhibitory concentration: > 100000 nM
Compound 4 gave a limit, no number; the forecaster's own chance of this, stated with the estimate: 40%; at least 2.5-fold (0.39 log units) between middle value and limit.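

In this assay compound 4 gives > 100000 nM, which is a limit of the assay and not a number. Compound 2 also sits at a limit, so no step can be read between compound 2 and compound 4. The compounds shown leave open whether methyl in place of dimethylamino changes the number at all, and in which direction.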